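The compounds below may be only part of what the source reports. "The series", "measured", "known", "first", "only" and "open" are said of these compounds alone.

Measured in a functional assay on HL-60 cells (Homo sapiens) for inhibition, read by MTT assay, with a stated time of 72 h; a lower number here means a stronger inhibitor, a higher number a weaker inhibitor:
- compound 1 `Cc1ccc(N2CCN(C(=O)c3oc(C)nc3-c3ccccc3)CC2)cc1`: > 1000 nM
- compound 2 `Cc1nc(-c2ccccc2)c(C(=O)N2CCN(c3cccc(F)c3)CC2)o1`: 45 nM

The value of compound 1, > 1000 nM, is a limit of the assay and not a number. For the measured compounds named here, compound 2, at 45 nM, therefore holds the only true number in this assay so far.

Next is compound 3 `COc1cc(OC)cc(N2CCN(C(=O)c3oc(C)nc3-c3ccccc3)CC2)c1`, with 3,5-dimethoxyphenyl in place of 3-fluorophenyl on an amine nitrogen in a ring.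

Going by the values given here, one measured step bears on this, as it changes the group at the same place. an at least 22-fold lower number from compound 1 to compound 2 (1.34 log units; beyond the scatter) is large and beyond the scatter, so this group can move the number widely. A single step gives no trend, however, so no change beyond the scatter is expected as the central case, with a wide margin either way.

The expected step is a 1.1-fold higher number from compound 2 to compound 3 (0.05 log units; within the scatter). For compound 3 the estimate is 50 nM, with an expected range of 10 nM to 300 nM.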

Compound 3, half-maximal inhibitory concentration: 19.2 nM
The estimate for compound 3 lay 2.6-fold (0.42 log units) above the measured number; the range from low to high includes it.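

In this assay, exchanging 3-fluorophenyl for 3,5-dimethoxyphenyl on the amine nitrogen in the ring gives a 2.3-fold lower number from compound 2 to compound 3 (0.37 log units; beyond the scatter), a modest step, so this position tolerates a group with more heavy atoms and still improves on the number of compound 2. The wider comparison gives an at least 52-fold lower number from compound 1 to compound 3 (1.71 log units; beyond the scatter), so two different replacements for 4-methylphenyl now stand far from compound 1 in the same direction. Compound 1 carries a limit and not a number, so both steps from it are bounds only: the limit of > 1000 nM in this assay, at which 1 of the 3 values shown sits.

The compounds shown leave open whether a single methoxy group on the phenyl ring would read like the pair, and how an amine or a carboxylic acid there would read. On these data alone, the shared core is the same throughout, so the effect of any change outside this position remains open.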